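The source may report more compounds than this note shows. Statements on the series, on what has been measured and on what is new or still open speak of the compounds shown alone.

Measured in a functional assay on NCI-H460 cells (Homo sapiens) for cytotoxicity, read by sulforhodamine B assay, with a stated time of 3 days; a higher number here means a weaker inhibitor, a lower number a stronger inhibitor:
compound 1 `OCc1cn(Cc2ccc(Cl)cc2)c2ccccc12`: 16 nM
compound 2 `OCc1cn(Cc2ccc(Cl)cc2)c2ccc(Cl)cc12`: 5750 nM

Of these two, compound 2 has the higher number, which makes it the weaker inhibitor in this assay. Compound 3 `COc1ccc2c(c1)c(CO)cn2Cc1ccc(Cl)cc1` keeps the rest of compound 2 but has methoxy in place of chloro on an aromatic carbon.

Within the data shown here, only one measured step bears on this change: a 360-fold higher number from compound 1 to compound 2 (2.56 log units; beyond the scatter), a large step that came with chloro in place of hydrogen on an aromatic carbon. Among the measured compounds shown here, that step shows what chloro did at this carbon, but it says nothing directly about methoxy, and no measured compound carries that group. Compound 3 still has a group other than hydrogen at this carbon, so its number is expected to stay closer to compound 2, at 5750 nM, than to compound 1, at 16 nM. A moderate move towards a lower number is expected, though with little certainty. The estimated change is a 3.8-fold lower number from compound 2 to compound 3 (0.58 log units; beyond the scatter). For compound 3 the estimated value is 1500 nM, with an expected range of 100 nM to 10000 nM.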

Compound 3, half-maximal inhibitory concentration: 1510 nM
For compound 3 the middle estimate is 1.0-fold (0.00 log units) below the measured one; the measured number falls inside the stated range.
By their numbers in this assay, from the lowest: compound 1; then compound 3; then compound 2.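

In this assay, a second group at this carbon now allows two substituents to be compared directly, and methoxy in place of chloro gives a 3.8-fold lower number from compound 2 to compound 3 (0.58 log units; beyond the scatter) as a modest but real shift, so the identity of the group matters and not only whether one is present. That shift is small beside a 94-fold higher number from compound 1 to compound 3 (1.97 log units; beyond the scatter) as the step from plain hydrogen to methoxy, so methoxy, like chloro, leaves the number far from that of the unsubstituted compound. Compound 1, with hydrogen at this carbon, therefore remains the strongest of the three, with its steps to both substituted compounds beyond the scatter.

No measurement shown here accounts for why either group weakens the compound so strongly or why methoxy weakens it less than chloro.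

The compounds shown leave open whether fluoro, hydroxyl, an amine or a carboxylic acid at this carbon would bring the number closer to that of compound 1 or push it further away. They also leave open whether a longer chain, such as ethoxy, would continue the shift seen on going from chloro to methoxy.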